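Fluoro to trifluoromethyl in a cytotoxic series

The source may report more compounds than this note shows. Statements on the series, on what has been measured and on what is new or still open speak of the compounds shown alone.

Tested in a functional assay on QGY-7703 cells (Homo sapiens) for cytotoxicity, read by MTT assay, with a stated time of 24 h (on this read-out lower numbers stand for stronger inhibition and higher numbers for weaker inhibition), compound 1 (`O=C1/C(=C/c2ccncc2)CN(S(=O)(=O)c2ccccc2)C/C1=C\c1ccccc1F`) reads 8400 nM and lies within the scatter of both measured relatives. Compound 2 (`O=C1/C(=C/c2ccncc2)CN(S(=O)(=O)c2ccc(Br)cc2)C/C1=C\c1ccccc1F`) reads 11500 nM and compound 3 (`N#Cc1ccc(S(=O)(=O)N2C/C(=C\c3ccncc3)C(=O)/C(=C/c3ccccc3F)C2)cc1`) reads 8500 nM on the same read-out. Bromo in place of hydrogen on an aromatic carbon gives a 1.4-fold higher number from compound 1 to compound 2 (0.14 log units; within the scatter) and cyano in place of hydrogen gives a 1.0-fold higher number from compound 1 to compound 3 (0.01 log units; within the scatter) while cyano in place of bromo gives a 1.4-fold lower number from compound 2 to compound 3 (0.13 log units; within the scatter) to complete the set. Compound 4 (`O=C1/C(=C/c2ccncc2)CN(S(=O)(=O)c2ccccc2)C/C1=C\c1ccccc1C(F)(F)F`) is made from compound 1 by turning 2-fluorophenyl into 2-(trifluoromethyl)phenyl (trifluoromethyl in place of fluoro on an aromatic carbon) with trifluoromethyl in place of fluoro on an aromatic carbon, ortho to a large group. All three measured steps leave the 2-fluorophenyl group untouched, so they bear on this change only indirectly. Going by the values given here, they show a set whose readings stayed within the scatter, and no measured compound varies the fluoro itself. With no direction indicated, the expected step is a 1.1-fold higher number from compound 1 to compound 4 (0.03 log units; within the scatter) and thus none beyond the scatter, anchored on compound 1 at 8400 nM as the starting point. For compound 4 the estimated value in this assay is 9000 nM (expected range 3800 nM to 20000 nM).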

Compound 4, half-maximal inhibitory concentration: 6210 nM
For compound 4 the middle estimate is 1.4-fold (0.16 log units) above the measured one, and the stated range covers the measured number.
By their numbers in this assay, from the lowest: compounds 4, 1, 3 and 2 (each within the scatter of the next).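

In this assay, going by these compounds alone, the 2-fluorophenyl group, which all the earlier steps left untouched, is now varied directly, and the step to 2-(trifluoromethyl)phenyl gives a 1.4-fold lower number from compound 1 to compound 4 (0.13 log units; within the scatter). The reading therefore stays within the scatter when trifluoromethyl replaces fluoro on this aromatic carbon, ortho to a large group, so this position accepts the larger substituent without a measurable shift, just as the bromo and cyano steps at the other varied place produced none. No measurement here explains why the reading holds, and with a single step at this position, nothing can be said about what governs it.

The compounds shown leave open whether an amine, a carboxylic acid or a longer chain in place of fluoro would also stay within the scatter, and whether the 2-(trifluoromethyl)phenyl group would read the same alongside the bromo of compound 2 or the cyano of compound 3. Since every step shown lies within the scatter, they also identify no group at either varied place that moves the reading beyond it.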